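Pyrazinyl sulfone in place of fluorophenyl on a sulfonylurea-site blocker

The compounds below may be only part of what the source reports. "The series", "measured", "known", "first", "only" and "open" are said of these compounds alone.

Measured compounds:
compound 1 `CC(O)(C(=O)Nc1ccc(S(=O)(=O)c2ccc(F)cc2)cc1)C(F)(F)F` — 8600 nM
compound 2 `CC(O)(C(=O)Nc1ccc(S(=O)(=O)c2ccccc2)c(Cl)c1)C(F)(F)F` — 2200 nM

Of the compounds shown here, two have been measured in a functional assay (Cavia porcellus) with sulfonylurea receptors; K-ATP channels (Homo sapiens) as the target; on this read-out lower numbers stand for stronger inhibition and higher numbers for weaker inhibition. Compound 1 `CC(O)(C(=O)Nc1ccc(S(=O)(=O)c2ccc(F)cc2)cc1)C(F)(F)F` gives 8600 nM and stands at the highest number of the two. Its nearest neighbour is compound 2 `CC(O)(C(=O)Nc1ccc(S(=O)(=O)c2ccccc2)c(Cl)c1)C(F)(F)F`, which in this assay gives 2200 nM; the gap between the two lies beyond the usual scatter, so compound 2 is the stronger inhibitor of the pair. Among the measured compounds shown here, compound 2 differs from compound 1 in more than one place, so no single step between them can be read.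

Compound 3 `CC(O)(C(=O)Nc1ccc(S(=O)(=O)c2cnccn2)cc1)C(F)(F)F` has not yet been measured. It differs from compound 1 in one place: pyrazin-2-yl in place of 4-fluorophenyl on a sulfonyl sulfur. For the measured compounds named here, no measured pair shows what such a ring exchange on the sulfonyl sulfur does in this assay, so the direction of the step is open. The expectation for compound 3 is a step that is small, if any, and on the weaker side, as a 1.4-fold higher number from compound 1 to compound 3 (0.14 log units; within the scatter). The estimate for compound 3 in this assay is 12000 nM, with a range from 4000 nM to 40000 nM.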

Compound 3, half-maximal inhibitory concentration: 12000 nM
The estimate for compound 3 equals the measured number at the digits printed, and the stated range covers the measured number.
By their numbers in this assay, from the lowest: compound 2; then compounds 1 and 3 (each within the scatter of the next).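

In this assay, among the compounds shown here, a 1.4-fold higher number from compound 1 to compound 3 (0.14 log units; within the scatter) gives the first readable step at this position, and it lies within the scatter, so compound 1 and compound 3 cannot be told apart in this read-out. For the compounds shown here, the exchange replaces a ring of carbon only, with no hydrogen-bond acceptors, by pyrazin-2-yl, with its two ring nitrogens counted as hydrogen-bond acceptors; on a sulfonyl sulfur whose other neighbour is aromatic carbon, this one exchange leaves no measurable step, though a single pair sets no rule for other groups. Nothing available gives a reason for this outcome.

From the compounds shown here alone, whether the same holds for other groups on the sulfonyl sulfur, such as pyridin-3-yl, cyclohexyl or a short alkyl chain, remains open. Going by these compounds, compound 2 differs from compound 1 and from compound 3 in more than one place, so neither step can be read, and what each of its differences contributes also stays open.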